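The source may hold more compounds than are shown below. What is called first, only, known or untested is meant among the compounds shown, and "the series" means these compounds.

Of the compounds shown here, three have been measured in an assay for inhibition of Fatty-acid amide hydrolase 1 (Rattus norvegicus); on this read-out lower numbers stand for stronger inhibition and higher numbers for weaker inhibition. Compound 1 `O=C(CCc1ccc(-c2ccccc2)cc1)c1ncc(-c2ccncc2)o1` gives 2.3 nM, compound 2 `CNC(=O)c1cnc(C(=O)CCc2ccc(COc3ccccc3)cc2)o1` gives 3.6 nM, and compound 3 `COC(=O)c1ccc(-c2cnc(C(=O)CCc3ccc(-c4ccccc4)cc3)o2)nc1` gives 2.2 nM. Compound 2 thus shows the highest of the three numbers, although its gaps to compound 1 and to compound 3 both lie within the scatter. For the measured compounds named here, the one single-place step on record, a 1.0-fold lower number from compound 1 to compound 3 (0.02 log units; within the scatter), exchanges one pyridyl group on the shared core for another and leaves the number essentially unchanged.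

Compound 4 `N#Cc1cccc(-c2cnc(C(=O)CCc3ccc(COc4ccccc4)cc3)o2)n1` differs from compound 2 by 6-cyanopyridin-2-yl in place of methylcarbamoyl on an aromatic carbon. Since compound 1 and compound 3, which both carry a pyridyl group at this position, sit within the scatter of compound 2, no step beyond the scatter is expected, and compound 4 is estimated to give 2.5 nM, between 0.8 nM and 8 nM. The expected step from compound 2 to compound 4 is therefore a 1.4-fold lower number from compound 2 to compound 4 (0.16 log units; within the scatter).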

Compound 4, inhibition constant: 0.56 nM
For compound 4 the middle estimate is 4.5-fold (0.65 log units) above the measured one, and the stated range ends above it.
By their numbers in this assay, from the lowest: compound 4; then compounds 3, 1 and 2 (each within the scatter of the next).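

In this assay, for the compounds shown here, 6-cyanopyridin-2-yl in place of methylcarbamoyl on this aromatic carbon, next to the ring oxygen, gives a 6.4-fold lower number from compound 2 to compound 4 (0.81 log units; beyond the scatter), the only step at this position that lies beyond the scatter. The earlier exchange of one pyridyl group for another, a 1.0-fold lower number from compound 1 to compound 3 (0.02 log units; within the scatter), had shown no such movement, so the number here does respond to the group placed at this position. No measurement on hand explains the step. As far as these compounds go, it remains open whether the nitrile or the pyridine ring accounts for it, and how a plain pyridin-2-yl or a carboxylic acid would read in the same place.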